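Benzimidazole-to-indole swap on the piperazine-linked chain

The source may hold more compounds than are shown below. What is called first, only, known or untested is meant among the compounds shown, and "the series" means these compounds.

Measured so far:
compound 1 `O=C(C(c1ccccc1)c1ccccc1)N1CCN(CCCn2c(=O)[nH]c3ccccc32)CC1` — 7800 nM
compound 2 `O=c1[nH]c2ccccc2n1CCCN1CCN(S(=O)(=O)c2ccc(F)cc2)CC1` — > 10000 nM
compound 3 `Cc1nc2ccccc2n1CCCCN1CCN(C(c2ccccc2)c2ccccc2)CC1` — 850 nM

In an assay on RPMI-8226 cells for antagonist activity at P2X purinoceptor 7 (Homo sapiens), read by calcium flux (on this read-out lower numbers stand for stronger inhibition and higher numbers for weaker inhibition), compound 1 gives 7800 nM. Compound 2 reaches only the limit of > 10000 nM in this assay, at which 1 of the 3 values shown sits, and no number is available for it. Compound 3 gives 850 nM in this assay, the lowest of the two numbers; the nearest number, that of compound 1, stands higher by a gap beyond the usual scatter, so compound 3 is the clearer of the two measured numbers.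

Compound 4 `Fc1cc2ccn(CCCCN3CCN(C(c4ccccc4)c4ccccc4)CC3)c2cc1F` is compound 3 with a group of 11 heavy atoms (8 carbon, 1 nitrogen, 2 fluorine; one five-membered aromatic ring with 1 hetero atom, one six-membered aromatic ring of carbon only) in place of a group of 10 heavy atoms (8 carbon, 2 nitrogen; one five-membered aromatic ring with 2 hetero atoms, one six-membered aromatic ring of carbon only), on a saturated chain carbon, four bonds along the chain from an amine nitrogen in a ring. For the measured compounds named here, no measured pair shares this change or a related one, so the size of the step cannot be read from the compounds already measured. The expectation is that the step from compound 3 to compound 4 in this assay remains within the scatter, a 1.2-fold lower number from compound 3 to compound 4 (0.08 log units; within the scatter), with no clear direction. Compound 4 is therefore estimated at 700 nM in this assay, expected to fall between 200 nM and 2500 nM.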

Compound 4, half-maximal inhibitory concentration: 130 nM
Beside the measured number, compound 4's estimate is 5.4-fold (0.73 log units) above it, and the stated range ends above it.
By their numbers in this assay, from the lowest: compound 4; then compound 3; then compound 1. At a limit, above all of these: compound 2.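

In this assay the group on the saturated chain carbon, four bonds along the chain from an amine nitrogen in a ring, can be exchanged with a real effect: losing 2-methyl-1H-benzimidazol-1-yl for the difluorinated group gives a 6.5-fold lower number from compound 3 to compound 4 (0.82 log units; beyond the scatter) and thus a step beyond the scatter. The entering group carries one hydrogen-bond acceptor where the leaving group carries two, so in this pair the lower number does not depend on keeping the second acceptor. No measurement shown here accounts for the size of this step.

The step changes the ring nitrogen, the methyl and the two fluorines at once, so the share of each cannot be separated. From the compounds shown here alone, whether chlorine or a methoxy group in place of the fluorines, or a shorter chain, would hold the lower number remains open.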